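The source may report more compounds than this note shows. Statements on the series, on what has been measured and on what is new or still open speak of the compounds shown alone.

Series values in an in vitro ADME assay on microsomes from Gut (Homo sapiens) for metabolic stability, in the presence of a further agent that is not named here; a higher number here means faster removal of the compound, a lower number slower removal:

- compound 1 (`CCCOc1cccc(Cn2c(C(=O)NCC(C)(C)CO)cc3cc(C#N)ccc32)c1`) : 45 mL.min-1.g-1
- compound 2 (`COc1ccc(C(C)(C)C)cc1Cn1c(C(=O)NCC2(CO)CC2)cc2cc(C#N)ccc21`) : 26 mL.min-1.g-1
- compound 3 (`CC(C)(O)CCNC(=O)c1cc2cc(C#N)ccc2n1Cc1cccc(OC(F)(F)F)c1`) : 9 mL.min-1.g-1

Compound 3 stands lowest of the three, and the higher numbers of compound 1 and compound 2 both lie beyond the scatter from it. These three compounds differ in more than one place, so no single structural change can be read from their values.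

The next compound to be measured in this assay is compound 4 (`N#Cc1ccc2c(c1)cc(C(=O)NCCC1(O)CCC1)n2Cc1cccc(OC(F)(F)F)c1`). It departs from compound 3 in one place: 1-hydroxycyclobutyl in place of 1-hydroxy-1-methylethyl on a saturated chain carbon, two bonds along the chain from an amide-type nitrogen. This places 1-hydroxycyclobutyl in place of 1-hydroxy-1-methylethyl on a saturated chain carbon, two bonds along the chain from an amide-type nitrogen.

Going by the values given here, the series offers no measured one-place step to serve as a guide, so the expectation starts from compound 3 at 9 mL.min-1.g-1 and rests on the small size of the change. A modest rise is expected, probably not beyond the scatter, with the low value of compound 3 as the likeliest anchor. The estimated step is a 1.4-fold higher number from compound 3 to compound 4 (0.16 log units; within the scatter). For compound 4 the expected value is 13 mL.min-1.g-1, with an estimated range of 6 mL.min-1.g-1 to 28 mL.min-1.g-1.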

Compound 4, intrinsic clearance in microsomes: < 6 mL.min-1.g-1
Compound 4 ended at the assay's limit (the forecaster's own chance of this, stated with the estimate: 5%); at least 2.1-fold (0.33 log units) between middle value and limit.
By their numbers in this assay, from the lowest: compound 3; then compounds 2 and 1 (each within the scatter of the next). At a limit, below all of these: compound 4.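

Going by these compounds alone, this is the first one-place step: in this assay, 1-hydroxycyclobutyl in place of 1-hydroxy-1-methylethyl, on a saturated chain carbon two bonds along the chain from an amide-type nitrogen, gives an at least 1.5-fold lower number from compound 3 to compound 4 (0.17 log units; that floor lies within the scatter). Compound 4 reads < 6 mL.min-1.g-1, which is a limit of the assay and not a number. The step therefore shows that this position accepts the four-membered carbon ring with no rise in the read-out, though its full size stays unfixed because the value is a limit: the limit of < 6 mL.min-1.g-1 in this assay, at which 1 of the 4 values shown sits.

This single step gives no cause for the change and sets no trend, and it leaves open whether a cyclopentyl ring, a longer chain, or an amine or carboxylic acid in place of the hydroxyl would hold the read-out this low. From the compounds shown here alone, whether 1-hydroxycyclobutyl would act in the same direction in the side-chain position of compound 1 or compound 2, which differ from compound 3 in more than one place, also remains open.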